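Naphthalen-1-yl for phenoxy: permeability notes on the series

A few compounds are considered here, and "the series" means these few. Any claim that something is new, unique, unknown or untested is made for them only; others in the source may bear on it.

Three compounds of the shared core have numbers in an ADME assay for permeability, using PAMPA, with a stated time of 30 min, at pH 7.4; on this read-out higher numbers stand for higher permeability and lower numbers for lower permeability. Compound 1 `COc1ccc(Oc2ccc3c(NCCCNCc4cc(F)ccc4OC)ccnc3c2)cc1` gives 317 10^-6 cm/s. Compound 2 `COc1ccc(-c2ccc3c(NCCCNCc4cc(F)ccc4OC)ccnc3c2)cc1` gives 237 10^-6 cm/s. Compound 3 `COc1ccc(F)cc1CNCCCNc1ccnc2cc(Oc3ccccc3)ccc12` gives 317 10^-6 cm/s. The single-point steps among them are small: a 1.3-fold lower number from compound 1 to compound 2 (0.13 log units; within the scatter), no change at the digits printed from compound 1 to compound 3 (within the scatter) and a 1.3-fold higher number from compound 2 to compound 3 (0.13 log units; within the scatter). Compound 3 thus sits level with compound 1, and all three values lie within the scatter of one another, so no order among them can be read.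

Compound 4 `COc1ccc(F)cc1CNCCCNc1ccnc2cc(-c3cccc4ccccc34)ccc12` differs from compound 3 in one place: naphthalen-1-yl in place of phenoxy on an aromatic carbon. Among the measured compounds shown here, the steps that bear on this are the exchange of an aryl ether for a directly bound aryl, a 1.3-fold lower number from compound 1 to compound 2 (0.13 log units; within the scatter), and the reverse exchange with loss of the methoxy, a 1.3-fold higher number from compound 2 to compound 3 (0.13 log units; within the scatter); both are within the scatter. For the measured compounds named here, no measured step covers the addition of a second fused ring, so the data give no direction for that part of the change. On this basis a step of no more than the scatter is expected, a 1.1-fold lower number from compound 3 to compound 4 (0.05 log units; within the scatter), with a wider range to allow for the untested ring. For compound 4 in this assay the estimated value is 280 10^-6 cm/s, between 150 10^-6 cm/s and 450 10^-6 cm/s.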

Compound 4, apparent permeability: 237 10^-6 cm/s
Beside the measured number, compound 4's estimate is 1.2-fold (0.07 log units) above it; low and high end bracket the measured number.
By their numbers in this assay, from the lowest: compounds 2, 4, 1 and 3 (each within the scatter of the next).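

In this assay, among the compounds shown here, this position, an aromatic carbon of a six-membered aromatic ring of carbon only, now carries 2 six-membered aromatic rings of carbon only in one group, and a 1.3-fold lower number from compound 3 to compound 4 (0.13 log units; within the scatter) is the step that covers this change, which the earlier steps did not. The same reading holds against the two methoxy-bearing groups, with no change at the digits printed from compound 2 to compound 4 (within the scatter) and a 1.3-fold lower number from compound 1 to compound 4 (0.13 log units; within the scatter) as the steps, so naphthalen-1-yl, with 10 heavy atoms and 0 hydrogen-bond acceptors, cannot be told apart from phenoxy, 4-methoxyphenyl or 4-methoxyphenoxy on this read-out. Nothing measured alongside these numbers accounts for the result.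

As far as these compounds go, all four groups at this position are aryl or aryloxy groups with no net charge, so an aminomethyl group, a carboxylic acid or a morpholine here stays open, as does naphthalen-2-yl. The four compounds differ only at this position, so they say nothing about a longer or shorter chain or about any other place on the shared core.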